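The compounds below may be only part of what the source reports. "The series", "measured", "known", "first", "only" and "open" are said of these compounds alone.

Compound 2 `O=C(CC1c2ccccc2N=C(SCCCCCN2CCCC2)N1c1ccccc1)NCc1ccc(F)cc1` gives 40% in an assay on cells for inhibition of Voltage-dependent T-type calcium channel subunit alpha-1H (Homo sapiens), read by patch clamp, tested at 10 uM; a higher number here means more inhibition at the concentration tested (going by the name of the read-out), a lower number less inhibition. Compound 1 `O=C(CC1c2ccccc2N=C(SCCCCCN2CCCC2)N1c1ccc(-c2ccc(F)cc2)cc1)NCc1ccc(F)cc1` carries 4-fluorophenyl in place of hydrogen on an aromatic carbon; in this assay compound 1 gives 76.6%, the step being a number 36.6 percentage points higher from compound 2 to compound 1 (beyond the scatter). Compound 3 `CN(C)CCCCCSC1=Nc2ccccc2C(CC(=O)NCc2ccc(F)cc2)N1c1ccccc1` differs from compound 2 by dimethylamino in place of pyrrolidin-1-yl on a saturated chain carbon, five bonds along the chain from a sulfur; in this assay compound 3 gives 7%, the step being a number 33 percentage points lower from compound 2 to compound 3 (beyond the scatter), which leaves compound 3 as the lowest number of the three. Compound 4 `CN(C)CCCCCSC1=Nc2ccccc2C(CC(=O)NCc2ccc(F)cc2)N1c1ccc(-c2ccc(F)cc2)cc1` is not yet measured. It differs from compound 3 by 4-fluorophenyl in place of hydrogen on an aromatic carbon, the same change as that from compound 2 to compound 1, here made on the core of compound 3 rather than on that of compound 2. Among the measured compounds shown here, the step from compound 3 to compound 4 is expected to be of similar size, a number 33 percentage points higher from compound 3 to compound 4 (beyond the scatter), because the single comparable step a number 36.6 percentage points higher from compound 2 to compound 1 (beyond the scatter) is large; only that one pair supports the expectation. Compound 4 is accordingly estimated at 40%, between 18% and 62%.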

Compound 4, a percentage reported as inhibition, at one concentration (the size of the read-out at that concentration, not a potency): 84.8%
Estimate against measurement, compound 4: 44.8 percentage points below, outside the stated range (above it).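

In this assay the 4-fluorophenyl change keeps its direction on the second core but not its size, the new step being a number 77.8 percentage points higher from compound 3 to compound 4 (beyond the scatter): the same change on two cores in this assay, a number 36.6 percentage points higher (beyond the scatter) from compound 2 to compound 1 and a number 77.8 percentage points higher (beyond the scatter) from compound 3 to compound 4, 41.2 percentage points apart, beyond the scatter of two such steps

Dimethylamino in place of pyrrolidin-1-yl also depends on the core, giving a number 8.2 percentage points higher from compound 1 to compound 4 (within the scatter), so the drop seen without the 4-fluorophenyl group does not recur with it: the same change on two cores in this assay, a number 33 percentage points lower (beyond the scatter) from compound 2 to compound 3 and a number 8.2 percentage points higher (within the scatter) from compound 1 to compound 4, 41.2 percentage points apart, beyond the scatter of two such steps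

These four compounds show that the two changes do not add independently in this series, but they do not show why, and they give no rule for any other core.

Open, as far as these compounds go, is whether the same dependence holds with another amine on the chain, such as piperidin-1-yl or morpholin-4-yl. From the compounds shown here alone, a shorter or longer chain to the sulfur is also open.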